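Swapping the Anilino Substituent in a Weak Kinase-Type Series

This account rests on a few compounds, and the source may have more. Where it says the series, first, only, none or still open, it means among the compounds named here.

The compounds measured so far:
compound 1, `COc1ccc(Nc2nc(Oc3cccc(NC(=O)C=C(C)C)c3)c3sccc3n2)cc1`, 18100 nM
compound 2, `COc1ccc(Nc2nc(Oc3cccc(NC(=O)/C=C/C(C)C)c3)c3sccc3n2)cc1`, 37900 nM
compound 3, `CC/C=C/C(=O)Nc1cccc(Oc2nc(Nc3cccc(OC)c3)nc3ccsc23)c1`, 19600 nM

Among the compounds with values here, in a functional assay on A549 cells (Homo sapiens) for inhibition, read by MTT assay, with a stated time of 72 h (on this read-out higher numbers stand for weaker inhibition and lower numbers for stronger inhibition), compound 2 gives the highest of the three numbers, though its gap to compound 3 lies within the scatter and only the step of a 2.1-fold higher number from compound 1 to compound 2 (0.32 log units; beyond the scatter) is beyond it. That one measured step concerns the acrylamide tail and not the part that changes here.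

Compound 4, `CC(C)/C=C/C(=O)Nc1cccc(Oc2nc(Nc3cccc(C#N)c3)nc3ccsc23)c1`, has not been measured. It differs from compound 2 in one place: 3-cyanophenyl in place of 4-methoxyphenyl on a nitrogen on an aromatic ring. Within the data shown here, no measured pair bears on this change. Among the measured compounds shown here, compound 3 carries a methoxy group at a different position and a different chain, so the two values show only that compound 3 and compound 2 sit within the scatter of each other. The three numbers as a whole are close, so the expectation for compound 4 is a number near compound 2, with wide uncertainty; the expected step is a 1.5-fold lower number from compound 2 to compound 4 (0.18 log units; within the scatter). Compound 4 is therefore estimated at 25000 nM, within a range from 6000 nM to 90000 nM.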

Compound 4, half-maximal inhibitory concentration: 19000 nM
Estimate against measurement, compound 4: 1.3-fold (0.12 log units) above; low and high end bracket the measured number.
By their numbers in this assay, from the lowest: compounds 1, 4, 3 and 2 (each within the scatter of the next, the first and the last beyond it).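

In this assay, within the data shown here, the first reading at this position is a 2.0-fold lower number from compound 2 to compound 4 (0.30 log units; within the scatter), so the change from (4-methoxyphenyl)amino to (3-cyanophenyl)amino cannot be told from repeat scatter. On this pair, two aryl groups of the same heavy-atom count, each with one hydrogen-bond acceptor, give numbers that this read-out does not separate, although the nitrile and the methoxy group carry different numbers in their names, so the pair cannot divide the effect of the group from that of its placing. Nothing measured here offers an explanation for this result.

Going by these compounds, it remains open whether an amine, a carboxylic acid or a plain unsubstituted phenyl on that nitrogen would give a step beyond the scatter. Also open, on these data alone, is whether the same swap reads alike with the 2-methylprop-1-en-1-yl tail of compound 1.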